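A few compounds are considered here, and "the series" means these few. Any claim that something is new, unique, unknown or untested is made for them only; others in the source may bear on it.

Measured so far in an assay (Equus caballus) for inhibition of Thromboxane-A synthase (Homo sapiens), using microsomes; on this read-out lower numbers stand for stronger inhibition and higher numbers for weaker inhibition:
compound 1, `Cc1ccsc1/C(=C/CCCCC(=O)O)c1cccnc1`, 29 nM
compound 2, `O=C(O)CCCC/C=C(/c1ccc(Br)cc1)c1cccnc1`, 82 nM

For the measured compounds named here, compound 2 has the higher of the two numbers; its only neighbour is compound 1, and the step of a 2.8-fold higher number from compound 1 to compound 2 (0.45 log units; beyond the scatter) lies beyond the scatter. Compound 3, `O=C(O)CCCC/C=C(\c1cccnc1)c1cccs1`, is not yet measured. Its change from compound 2 is thiophen-2-yl in place of 4-bromophenyl on a double-bonded chain carbon bound to an aromatic carbon and a double-bonded chain carbon. Going by the values given here, the single measured step that bears on this change is a 2.8-fold higher number from compound 1 to compound 2 (0.45 log units; beyond the scatter), in which the five-membered aromatic ring at this place gave way to the six-membered one and the number rose. Compound 3 brings the five-membered aromatic ring back, now without the methyl of compound 1, so the change largely reverses the measured step. A fall in the number is therefore expected for compound 3, and the estimated step is a 2.3-fold lower number from compound 2 to compound 3 (0.37 log units; beyond the scatter). For compound 3 the expected value in this assay is 35 nM, within 15 nM to 85 nM.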

Compound 3, half-maximal inhibitory concentration: 20 nM
Beside the measured number, compound 3's estimate is 1.8-fold (0.24 log units) above it; low and high end bracket the measured number.
By their numbers in this assay, from the lowest: compounds 3 and 1 (each within the scatter of the next); then compound 2.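

In this assay, thiophen-2-yl in place of 4-bromophenyl on a double-bonded chain carbon bound to an aromatic carbon and a double-bonded chain carbon gives a 4.1-fold lower number from compound 2 to compound 3 (0.61 log units; beyond the scatter), so the five-membered ring holds the advantage over 4-bromophenyl even without a methyl. Hydrogen in place of methyl on an aromatic carbon gives a 1.5-fold lower number from compound 1 to compound 3 (0.16 log units; within the scatter), which shows that the methyl of compound 1 is not needed to keep the number low in this series. No measurement here accounts for either step.

The compounds shown leave open whether an unsubstituted phenyl at this place would stand with compound 2 or with compound 1 and compound 3, and so whether the bromine or the ring accounts for the step. From the compounds shown here alone, how furan-2-yl would compare at this place also remains open.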